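Notes on the amide aryl change toward compound 4

The source may hold more compounds than are shown below. What is called first, only, known or untested is meant among the compounds shown, and "the series" means these compounds.

Compound 2 `C/C(=C\C(=O)Nc1ccc2nc(N3CCC(O)(C4CC4)CC3)nc(C)c2c1)c1ccc(Cl)cc1` holds the highest number of the three compounds measured in a functional assay on CHO-K1 cells for antagonist activity at melanin-concentrating hormone receptor 1 (Homo sapiens), read by inositol phosphate accumulation, with stated times of 10 min and 45 min; a lower number here means a stronger inhibitor, a higher number a weaker inhibitor: compound 2 gives 340 nM. For the measured compounds named here, compound 1 `C/C(=C\C(=O)Nc1ccc2nc(N3CCC(O)CC3)nc(C)c2c1)c1ccc(Cl)cc1` gives 227 nM, and the step of a 1.5-fold higher number from compound 1 to compound 2 (0.18 log units; within the scatter) is the only single-point change measured so far; it replaces hydrogen on a saturated ring carbon with cyclopropyl and leaves the carbonyl side of the molecule untouched. Compound 3 `Cc1nc(N2CCC(NS(=O)(=O)N(C)C)CC2)nc2ccc(NC(=O)/C=C/c3ccc(OC(F)(F)F)cc3)cc12` gives 31 nM; it differs from compound 2 in more than one place, so its gap to compound 2 cannot be assigned to any one change.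

Compound 4 `Cc1nc(N2CCC(O)(C3CC3)CC2)nc2ccc(NC(=O)/C=C/c3ccc(Cl)cc3Cl)cc12` differs from compound 2 by 2-(2,4-dichlorophenyl)ethenyl in place of 2-(4-chlorophenyl)prop-1-en-1-yl on a carbonyl carbon. Going by the values given here, no measured step touches this part of the molecule, so there is nothing to scale from; the one measured step, on a saturated ring carbon, was within the scatter. The expectation for compound 4 is therefore a number close to that of compound 2, with wide uncertainty in either direction. Compound 4 is estimated at 220 nM, range 60 nM to 800 nM. The expected step of a 1.5-fold lower number from compound 2 to compound 4 (0.19 log units; within the scatter) is thus none beyond the scatter.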

Compound 4, half-maximal inhibitory concentration: 575 nM
The estimate for compound 4 lay 2.6-fold (0.42 log units) below the measured number, and the stated range covers the measured number.
By their numbers in this assay, from the lowest: compound 3; then compounds 1, 2 and 4 (each within the scatter of the next, the first and the last beyond it).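

In this assay, for the compounds shown here, the first measured change on the carbonyl side of the series gives a 1.7-fold higher number from compound 2 to compound 4 (0.23 log units; within the scatter) and so cannot be told apart from repeat variation. At this carbonyl carbon, 2-(2,4-dichlorophenyl)ethenyl can therefore stand in place of 2-(4-chlorophenyl)prop-1-en-1-yl without a readable shift, and the two groups match in heavy-atom count, donors and acceptors while differing in their carbon and chlorine make-up. No measurement at hand bears on the reason for this result.

This one step alters the chain and the chlorine count together, so the contribution of each remains unresolved. From the compounds shown here alone, it also remains open whether an amine or a carboxylic acid on the aryl ring, in a group otherwise like these, would move the number beyond the scatter.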